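Ethyl to Isopropyl on the Core Nitrogen

The compounds below may be only part of what the source reports. "The series", "measured", "known", "first", "only" and "open" are said of these compounds alone.

Of the compounds shown here, two sharing the same core have been measured so far. In an assay on cells for inhibition of Amine oxidase [flavin-containing] B (Homo sapiens), read by fluorescence, with stated times of 30 min and 15 min, tested at 1 uM (on this read-out higher numbers stand for more inhibition at the one concentration tested (going by the name of the read-out) and lower numbers for less inhibition), compound 1 `CCn1c(=O)[nH]c2ccc(OCCOc3ccc(Cl)cc3)cc21` gives 7.24%. In this assay compound 2 `CCn1c(=O)[nH]c2ccc(OCCOc3ccc(C(C)C)cc3)cc21` gives 19%. Among the measured compounds shown here, the only measured step runs between them: a number 11.8 percentage points higher from compound 1 to compound 2 (beyond the scatter). Compound 2 therefore stands highest of the two numbers, with compound 1 as its nearest neighbour by that step.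

Compound 3 `CC(C)c1ccc(OCCOc2ccc3[nH]c(=O)n(C(C)C)c3c2)cc1` differs from compound 2 by methyl in place of hydrogen on a saturated chain carbon bound to an aromatic nitrogen and a saturated chain carbon. For the measured compounds named here, no measured step touches this part of the molecule. Going by the values given here, the single known step, from compound 1 to compound 2, alters a different part of the structure, so it bears on the present change only as a sign of how far the read-out has moved at all within this small set. With nothing pointing in either direction, the step from compound 2 to compound 3 is expected to be no change at the digits printed from compound 2 to compound 3 (within the scatter), that is, no change beyond the scatter. Compound 3 is accordingly estimated at 19%, with a range from 5% to 35%.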

Compound 3, a percentage reported as inhibition, at one concentration (the size of the read-out at that concentration, not a potency): 14.1%
For compound 3 the middle estimate is 4.9 percentage points above the measured one; the range from low to high includes it.
By their numbers in this assay, from the lowest: compounds 1, 3 and 2 (each within the scatter of the next, the first and the last beyond it).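

In this assay, among the compounds shown here, the ethyl to isopropyl change gives a number 4.9 percentage points lower from compound 2 to compound 3 (within the scatter), so this is the first reading of how the read-out responds at this position, a saturated chain carbon bound to an aromatic nitrogen and a saturated chain carbon. Methyl in place of hydrogen here leaves the read-out within the scatter, unlike the chloro to isopropyl step on an aromatic carbon, which the earlier compounds showed to lie beyond it; at the one concentration tested, this position accepts the added methyl without a measurable consequence. The data offer no measurement that would explain this outcome or link it to any feature of the added methyl.

What the compounds shown leave open is whether a longer chain, such as n-butyl, or a chain ending in an amine or a carboxylic acid would also stay within the scatter at this position. For the compounds shown here, it also remains open whether ethyl to isopropyl would read the same with chloro on the aromatic carbon, since this change is seen only with isopropyl there.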